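Replacing the chloro of compound 2 with hydrogen

The source may hold more compounds than are shown below. What is called first, only, known or untested is meant among the compounds shown, and "the series" means these compounds.

Compound 1 `COc1ccc(-c2nc3sc(-c4ccccc4)cn3n2)cc1` gives 37%
Compound 2 `Clc1ccc(-c2cn3nc(-c4ccccc4)nc3s2)cc1` gives 28%

These numbers come from a functional assay on EKVX cells (Homo sapiens) for inhibition, read by sulforhodamine B assay, with a stated time of 48 h, tested at 10 uM (a lower number here means less inhibition of growth, a higher number more inhibition of growth at the concentration tested), and there compound 2 at 28% lies within the usual scatter of compound 1 at 37% so the two cannot be ranked.

Compound 3 `c1ccc(-c2nc3sc(-c4ccccc4)cn3n2)cc1` has not yet been measured. It carries hydrogen in place of chloro on an aromatic carbon, para to a large group, which turns 4-chlorophenyl into phenyl (hydrogen in place of chloro on an aromatic carbon).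

For the measured compounds named here, no two measured compounds differ in one place only, so the data offer no direct guide to this change. The expectation therefore starts from compound 2 at 28% and assumes no clear direction. The estimated a number 1 percentage points lower from compound 2 to compound 3 (within the scatter) is expected to stay within the scatter. The estimate for compound 3 is 27% (expected range 12% to 42%).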

Compound 3, percent growth inhibition at one concentration: 21%
For compound 3 the middle estimate is 6 percentage points above the measured one; measured number inside the range.
By their numbers in this assay, from the lowest: compounds 3, 2 and 1 (each within the scatter of the next, the first and the last beyond it).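

In this assay, swapping chloro for hydrogen on the phenyl ring gives a number 7 percentage points lower from compound 2 to compound 3 (within the scatter), so at this position the chloro cannot be told apart from hydrogen. Swapping methoxy for hydrogen, on the other phenyl ring of compound 3, gives a number 16 percentage points lower from compound 1 to compound 3 (beyond the scatter), a modest step and the first change in this series that can be read beyond the scatter, which links the methoxy to more growth inhibition at the concentration tested. No measurement at hand explains either step.

From the compounds shown here alone, it remains open whether methoxy would have the same effect on the phenyl ring that carries chloro in compound 2. Going by these compounds, it is also open what an amine or a carboxylic acid would do on either ring.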